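Methoxy in Place of Methyl: Expecting Compound 4

The source may hold more compounds than are shown below. What is called first, only, known or untested is meant among the compounds shown, and "the series" means these compounds.

The measured compounds and their numbers in a functional assay on HCT-116 cells (Homo sapiens) for cytotoxicity, read by MTT assay, with a stated time of 72 h; on this read-out lower numbers stand for stronger inhibition and higher numbers for weaker inhibition:
- compound 1, `O=C1N/C(=N/c2csc(-c3ccc(Cl)cc3)c2)S/C1=C\c1ccccn1`, gives 21600 nM
- compound 2, `CN(C)c1ccc(/C=C2\S/C(=N\c3nc(-c4ccc(Cl)cc4)cs3)NC2=O)cc1`, gives 200 nM
- compound 3, `Cc1ccc(/C=C2\S/C(=N\c3nc(-c4ccc(Cl)cc4)cs3)NC2=O)cc1`, gives 500 nM

Compound 3 stands second highest of the three numbers. Its nearest neighbour is compound 2, with a lower number, and its furthest is compound 1, with a far higher number. For the measured compounds named here, the only single-point step among the measured compounds is a 2.5-fold higher number from compound 2 to compound 3 (0.40 log units; beyond the scatter); that step swaps one group on the same aromatic carbon that is changed here, so it is the one step that bears on the question.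

Compound 4 is `COc1ccc(/C=C2\S/C(=N\c3nc(-c4ccc(Cl)cc4)cs3)NC2=O)cc1`. It differs from compound 3 in one place: methoxy in place of methyl on an aromatic carbon. A group of two heavy atoms replaces one of a single carbon, and one hydrogen-bond acceptor enters.

Going by the values given here, the one comparable step was modest, and the exchange here is smaller than that one, so the expected step of a 1.3-fold lower number from compound 3 to compound 4 (0.10 log units; within the scatter) is small, most likely within the usual scatter, with any lean toward a lower number. Compound 4 is therefore estimated at 400 nM in this assay, within a range from 150 nM to 1200 nM.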

Compound 4, half-maximal inhibitory concentration: 400 nM
Beside the measured number, compound 4's estimate shows no gap at the digits printed, within the range that was stated.
By their numbers in this assay, from the lowest: compounds 2, 4 and 3 (each within the scatter of the next, the first and the last beyond it); then compound 1.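

In this assay, replacing methyl with methoxy on this aromatic carbon gives a 1.3-fold lower number from compound 3 to compound 4 (0.10 log units; within the scatter), so the entry of a hydrogen-bond acceptor with the methoxy group produces no change that can be told apart from ordinary assay variation. Replacing dimethylamino with methoxy at the same carbon gives a 2.0-fold higher number from compound 2 to compound 4 (0.30 log units; within the scatter), which also lies within the scatter, so compound 4 cannot be separated from either of the other two compounds, even though the step between those two, a 2.5-fold higher number from compound 2 to compound 3 (0.40 log units; beyond the scatter), lies beyond it. The third group on this carbon therefore shows that a measurable difference between two substituents does not mean that a new substituent will clearly differ from both, and nothing available here gives a reason for the size of these steps.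

On these data alone, it remains open whether much larger or charged groups at this carbon, such as a carboxylic acid, a primary amine or a longer chain like butoxy, would stay close to these numbers or move well away from them. As far as these compounds go, it also remains open whether methoxy would behave in the same way on another carbon of this six-membered ring.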